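This account rests on a few compounds, and the source may have more. Where it says the series, first, only, none or still open, it means among the compounds named here.

Going by the values given here, compound 1 `CCc1cccc2c(OC)c(-c3occ(C)c3C(=O)OC)ccc12` is the only member of the series with a number in a functional assay on MDA-MB-231 cells (Homo sapiens) for cytotoxicity, read by MTT assay, with a stated time of 72 h (a lower number here means that less compound is needed, a higher number that more compound is needed for the effect), where compound 1 gives 1.3 ug/mL. Among the compounds with values here, compound 2 `CCc1cccc2c(OC(C)=O)c(-c3occ(C)c3COC(C)=O)ccc12` differs from compound 1 in two places at once, so the pair yields no single step to read. In this assay compound 2 returns > 10 ug/mL, which is a limit of the assay and not a number. Compound 2 thus sits at the limit of > 10 ug/mL in this assay, at which 1 of the 2 values shown sits. Compound 3 `CCc1cccc2c(OC)c(-c3occ(C)c3COC(C)=O)ccc12` has not yet been measured in this assay. It differs from compound 1 by acetoxymethyl in place of methoxycarbonyl on an aromatic carbon; the methoxy group on the shared core is kept, and only the group on the five-membered aromatic ring with 1 oxygen is exchanged. The step of a 3.1-fold higher number from compound 1 to compound 3 (0.49 log units; beyond the scatter) is expected to be a loss, moderate but beyond the usual scatter. Compound 3 is expected to give about 4 ug/mL, with a range from 1.5 ug/mL to 10 ug/mL.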

Compound 3, concentration for half-maximal effect: 3.5 ug/mL
Estimate against measurement, compound 3: 1.1-fold (0.06 log units) above; the measured number falls inside the stated range.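

Acetoxymethyl in place of methoxycarbonyl on an aromatic carbon of the five-membered aromatic ring with 1 oxygen gives the first single-place reading at this position in this assay: a 2.7-fold higher number from compound 1 to compound 3 (0.43 log units; beyond the scatter) and thus a modest loss, with the effect still measurable as a number. Compound 3 also connects compound 2 to the series, since methyl in place of acetyl on an oxygen on an aromatic ring gives an at least 2.8-fold lower number from compound 2 to compound 3 (0.45 log units; beyond the scatter) and so shows that this second place also bears on the read-out with acetoxymethyl held constant. The entry for compound 2 is a limit of the assay and not a number: the limit of > 10 ug/mL in this assay, at which 1 of the 3 values shown sits.

From the compounds shown here alone, whether a hydroxymethyl or a carboxylic acid on the same aromatic carbon would keep the effect remains open. A free hydroxyl on the shared core in place of the methoxy group is also an open case.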